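A few compounds are considered here, and "the series" means these few. Any claim that something is new, unique, unknown or untested is made for them only; others in the source may bear on it.

Measured compounds:
compound 1, `CCCCNc1nc(N)nc2c1CNCC2`, 7.2 uM
compound 2, `CCCCNc1nc(N)nc2c1CN(C(=O)c1csc(N)n1)CC2`, 6.9 uM

In an assay on HEK293 cells for agonist activity at Toll-like receptor 8 (Homo sapiens), read by a luciferase reporter, with a stated time of 6 h (a lower number here means that less compound is needed, a higher number that more compound is needed for the effect), compound 1 gives 7.2 uM and compound 2 gives 6.9 uM. Compound 2 therefore has the lowest of the two numbers, but its nearest neighbour, compound 1, lies within the scatter of it, so no order between them can be read. For the measured compounds named here, the one measured step, a 1.0-fold lower number from compound 1 to compound 2 (0.02 log units; within the scatter), shows that the whole acyl group on the ring amine nitrogen changed the number by nothing beyond the scatter.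

Compound 3, `CCCCNc1nc(N)nc2c1CN(C(=O)c1scnc1C)CC2`, keeps that carbonyl but changes the ring on it: 4-methyl-1,3-thiazol-5-yl in place of 2-amino-1,3-thiazol-4-yl on a carbonyl carbon. Going by the values given here, the only step that bears on this change is the one from compound 1 to compound 2, and since adding the full (2-amino-1,3-thiazol-4-yl)carbonyl left the number within the scatter, exchanging one five-membered aromatic ring for another at the same carbonyl carbon is expected to move the number little. Compound 3 is therefore expected to show roughly a 1.0-fold higher number from compound 2 to compound 3 (0.01 log units; within the scatter), no step beyond the scatter. The estimate for compound 3 in this assay is 7 uM, between 2.5 uM and 20 uM.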

Compound 3, minimum effective concentration: 5.6 uM
Estimate against measurement, compound 3: 1.3-fold (0.10 log units) above; the measured number falls inside the stated range.
By their numbers in this assay, from the lowest: compounds 3, 2 and 1 (each within the scatter of the next).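

In this assay, the exchange of 2-amino-1,3-thiazol-4-yl for 4-methyl-1,3-thiazol-5-yl on a carbonyl carbon gives a 1.2-fold lower number from compound 2 to compound 3 (0.09 log units; within the scatter), so this place now tolerates a second ring without a readable shift, even though the entering group carries 0 hydrogen-bond donors and the leaving group carries 1. The second acyl group also stays close to the unsubstituted parent, with a 1.3-fold lower number from compound 1 to compound 3 (0.11 log units; within the scatter), which means that two different thiazolyl carbonyl groups, and not just one, leave the number indistinguishable from that of compound 1 when placed on the amine nitrogen in the ring. Nothing measured here offers an explanation for this flat picture.

On these data alone, whether any group on that nitrogen can move the number beyond the scatter remains open, for instance a simple benzoyl, an acyl group carrying a carboxylic acid or a primary amine, or a plain alkyl chain in place of the carbonyl. All three compounds also share the same butyl chain on the core, so the effect of a longer chain at that site, and how it would combine with these acyl groups, is left unanswered.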